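From 4-chlorobenzyl to 2-bromobenzyl: working notes

The compounds below may be only part of what the source reports. "The series", "measured", "known", "first", "only" and "open" are said of these compounds alone.

compound 1 `OC[C@H]1O[C@@H](n2cnc3c(NCc4cccc(F)c4)ncnc32)[C@H](O)[C@@H]1O` gives 7600 nM
compound 2 `OC[C@H]1O[C@@H](n2cnc3c(NCc4ccc(Cl)cc4)ncnc32)[C@H](O)[C@@H]1O` gives 218000 nM

Both values come from a functional assay on K562 cells (Homo sapiens) for antiproliferative activity, with a stated time of 72 h (on this read-out lower numbers stand for stronger inhibition and higher numbers for weaker inhibition), and compound 2 stands as the higher of the two. Going by the values given here, compound 3 `OC[C@H]1O[C@@H](n2cnc3c(NCc4ccccc4Br)ncnc32)[C@H](O)[C@@H]1O` is not yet measured and differs from compound 2 thus: 2-bromophenyl in place of 4-chlorophenyl on a saturated chain carbon bound to a nitrogen on an aromatic ring The one measured step (a 29-fold higher number from compound 1 to compound 2 (1.46 log units; beyond the scatter)) is large, beyond the scatter, and falls at this same place. Among the compounds with values here, no measured compound carries 2-bromophenyl, so a lower number of moderate size is expected, with wide uncertainty. The estimated step is a 5.5-fold lower number from compound 2 to compound 3 (0.74 log units; beyond the scatter) and remains only an expectation. Compound 3 is estimated at 40000 nM (range 6000 nM to 250000 nM).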

Compound 3, half-maximal inhibitory concentration: 10000 nM
Estimate against measurement, compound 3: 4.0-fold (0.60 log units) above; the range from low to high includes it.
By their numbers in this assay, from the lowest: compounds 1 and 3 (each within the scatter of the next); then compound 2.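

In this assay, 2-bromophenyl at this place brings a 22-fold lower number from compound 2 to compound 3 (1.34 log units; beyond the scatter), so the high number of compound 2 does not extend to every halogen-bearing phenyl group. Against 3-fluorophenyl, the same group gives a 1.3-fold higher number from compound 1 to compound 3 (0.12 log units; within the scatter), leaving 4-chlorophenyl alone apart among the three compounds. No supporting evidence bears on this difference.

The halogen and its place on the phenyl ring change together in both steps, so their contributions remain unseparated. A 2-chlorophenyl or 4-bromophenyl group at this place would separate them.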